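Aldehyde to Alcohol in a Macrocyclic Calpain-2 Inhibitor

A few compounds are considered here, and "the series" means these few. Any claim that something is new, unique, unknown or untested is made for them only; others in the source may bear on it.

Compound 1 `CC(C)C[C@@H]1NC(=O)[C@@H](NC(=O)OCc2ccccc2)Cc2ccc(cc2)OCCCCC[C@@H](C=O)NC1=O`: 180 nM
Compound 2 `CC(C)C[C@@H]1NC(=O)[C@@H](NC(=O)OCc2ccccc2)Cc2ccc(cc2)OCCCC[C@@H](C=O)NC1=O`: 30 nM

Of the compounds shown here, two have been measured in an assay on isolated protein for inhibition of Calpain-2 catalytic subunit (Homo sapiens), read by fluorescence; a higher number here means a weaker inhibitor, a lower number a stronger inhibitor. Compound 1 gives 180 nM, and compound 2 gives 30 nM, the lower of the two numbers; the gap between them lies beyond the scatter. Compound 3 `CC(C)C[C@@H]1NC(=O)[C@@H](NC(=O)OCc2ccccc2)Cc2ccc(cc2)OCCCC[C@@H](CO)NC1=O` keeps the core of compound 2 and differs in one place only: hydroxymethyl in place of formyl on a saturated ring carbon. No measured pair shows this change, so its effect cannot be read from the numbers shown. For compound 3 the expectation is a large step toward a weaker inhibitor, a 670-fold higher number from compound 2 to compound 3 (2.82 log units; beyond the scatter). Compound 3 is therefore estimated at 20000 nM, within 3000 nM to 100000 nM.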

Compound 3, half-maximal inhibitory concentration: 700 nM
Compound 3: middle estimate off by 29-fold (1.46 log units), on the high side; the measured number lies below the stated range.
By their numbers in this assay, from the lowest: compound 2; then compound 1; then compound 3.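

Replacing formyl with hydroxymethyl on this saturated ring carbon gives a 23-fold higher number from compound 2 to compound 3 (1.37 log units; beyond the scatter), so at this position the formyl group counts for a great deal. The loss is not total, however: compound 3 still gives 700 nM, so inhibition in the nanomolar range survives without any formyl group. Nothing measured here explains the step.

Going by these compounds, whether a carboxylic acid or an amine on this carbon would land nearer compound 2 or compound 3 stays open. So does whether the same swap would cost as much on the core of compound 1.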